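The source may hold more compounds than are shown below. What is called first, only, known or untested is meant among the compounds shown, and "the series" means these compounds.

Three compounds of one series share a core and differ only in the group carried on the triple-bonded carbon. Compound 1 `O=C(O)COc1ccc(Cl)cc1C#Cc1cccc(CO)c1F` gives 41 nM in an assay on CHO cells for displacement of a labelled ligand from prostaglandin D2 receptor 2 (Homo sapiens), read by scintillation counting; a lower number here means a stronger inhibitor, a higher number a weaker inhibitor. Compound 3 `CC1(O)c2ccc(C#Cc3cc(Cl)ccc3OCC(=O)O)cc2S(=O)(=O)C1(C)C` gives 28 nM in this assay, and compound 2 `O=C(O)COc1ccc(Cl)cc1C#Cc1ccncc1` gives 601 nM. Compound 2 therefore stands highest of the three numbers, the weakest inhibitor of the set; its nearest neighbour is compound 1, whose number lies well below it, beyond the scatter, and compound 3 lies further still below it, also beyond the scatter.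

Compound 4 `O=C(O)COc1ccc(Cl)cc1C#Cc1ccccc1` has not been measured. It differs from compound 2 in one place: phenyl in place of pyridin-4-yl on a triple-bonded carbon. Among the measured compounds shown here, no pair of measured compounds shows this same change, so its effect can only be expected, not read off. Since both measured neighbours with a carbon-only ring sit well below compound 2, the step is expected to run toward a lower number, of moderate size, though smaller than the gap to compound 1. Compound 2 to compound 4 is expected as a 4.0-fold lower number from compound 2 to compound 4 (0.60 log units; beyond the scatter). For compound 4 the estimate in this assay is 150 nM, with a range from 40 nM to 500 nM.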

Compound 4, inhibition constant: 108 nM
For compound 4 the middle estimate is 1.4-fold (0.14 log units) above the measured one; low and high end bracket the measured number.
By their numbers in this assay, from the lowest: compounds 3 and 1 (each within the scatter of the next); then compound 4; then compound 2.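

In this assay, among the compounds shown here, phenyl in place of pyridin-4-yl gives a 5.6-fold lower number from compound 2 to compound 4 (0.75 log units; beyond the scatter), the first direct reading of a change on this triple-bonded carbon. The two rings have the same count of heavy atoms and differ only in one ring atom, so exchanging a single ring nitrogen for carbon at this place is enough to move the number beyond the scatter. No measurement shown here accounts for the size or direction of this step.

The compounds shown leave open whether the result depends on where the ring nitrogen sits, which pyridin-3-yl or pyridin-2-yl on the same carbon would show. They also leave open what a single added group on the phenyl ring of compound 4, such as a fluorine, a hydroxymethyl or an amine, would do on its own.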